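The compounds below may be only part of what the source reports. "The series", "measured", "known", "first", "only" and "open" are said of these compounds alone.

Measured so far:
- compound 1, `COc1cccc2c1CCCC2NC(=O)C[C@@H]1C(=O)NC=CN1S(=O)(=O)c1ccc(C)cc1`: 36.1 nM in an in vitro functional assay on cells for antagonist activity at B1 bradykinin receptor (Homo sapiens), read by luminescence and calcium flux, with a stated time of 2 h; a higher number here means a weaker inhibitor, a lower number a stronger inhibitor
- compound 2, `Cc1ccc(S(=O)(=O)N2C=CNC(=O)[C@H]2CC(=O)N[C@H]2CCN(CC(C)C)CC2(C)C)cc1`: 0.86 nM in this assay

Compound 2 gives the lowest number of the two; compound 1 sits at a much higher number, a gap well beyond the scatter. Compound 3, `Cc1ccc(S(=O)(=O)N2C=CNC(=O)[C@H]2CC(=O)N[C@H]2CCN(C3CCCC3)CC2(C)C)cc1`, is not yet measured. It differs from compound 2 by cyclopentyl in place of isobutyl on an amine nitrogen in a ring. Among the measured compounds shown here, no measured pair shows this kind of change, so the step is open; a shift no larger than the scatter, in either direction, is the working expectation. For compound 3 the estimated result in this assay is 0.9 nM, with a range from 0.3 nM to 3 nM. The expected step is a 1.0-fold higher number from compound 2 to compound 3 (0.02 log units; within the scatter), essentially flat.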

Compound 3, half-maximal inhibitory concentration: 0.247 nM
Compound 3: middle estimate off by 3.6-fold (0.56 log units), on the high side; the measured number lies below the stated range.
By their numbers in this assay, from the lowest: compound 3; then compound 2; then compound 1.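

In this assay, the group on the amine nitrogen in the ring still moves the result at this low level: cyclopentyl in place of isobutyl gives a 3.5-fold lower number from compound 2 to compound 3 (0.54 log units; beyond the scatter). In this single pair, the ring and the extra carbon are tolerated, and the cyclic group gives the lower number. No available evidence bears on the reason for this step.

Going by these compounds, whether cyclobutyl or cyclohexyl would extend the step remains open. So does the outcome with a tetrahydropyranyl ring or a plain methyl on this nitrogen.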